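A few compounds are considered here, and "the series" means these few. Any claim that something is new, unique, unknown or untested is made for them only; others in the source may bear on it.

Measured compounds:
compound 1 `Cc1ccc(S(=O)(=O)c2cnc3cc(F)ccc3c2-c2ccc(F)cc2)cc1C`: 9.25 mL/min
compound 2 `O=S(=O)(c1ccc(F)cc1)c1cnc2cc(F)ccc2c1-c1ccc(F)cc1`: 1.34 mL/min
compound 3 `O=S(=O)(c1ccc(F)cc1)c1cnc2cc(F)ccc2c1-c1ccc(Cl)cc1`: 1.23 mL/min

Three compounds on a shared core were tested in an ADME assay on microsomes from liver (Homo sapiens) for metabolic stability, tested at 2.5 uM; a lower number here means slower removal, a higher number faster removal of the compound. Compound 2 gives 1.34 mL/min, and compound 3, which differs from it by chloro in place of fluoro on an aromatic carbon, gives 1.23 mL/min, so a 1.1-fold lower number from compound 2 to compound 3 (0.04 log units; within the scatter). Compound 1 differs from compound 2 by 3,4-dimethylphenyl in place of 4-fluorophenyl on a sulfonyl sulfur. Compound 1 gives 9.25 mL/min, which is a 6.9-fold higher number from compound 2 to compound 1 (0.84 log units; beyond the scatter).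

Compound 4 `Cc1ccc(S(=O)(=O)c2cnc3cc(F)ccc3c2-c2ccc(Cl)cc2)cc1C` is not yet measured in this assay. It differs from compound 3 by 3,4-dimethylphenyl in place of 4-fluorophenyl on a sulfonyl sulfur, the same change that carries compound 2 to compound 1. Since the cores of compound 2 and compound 3 sit within the scatter of each other in this assay, the step is expected to repeat: from compound 3 to compound 4 the estimate is a 6.9-fold higher number from compound 3 to compound 4 (0.84 log units; beyond the scatter), resting on a 6.9-fold higher number from compound 2 to compound 1 (0.84 log units; beyond the scatter). For compound 4 the expected value in this assay is 8.5 mL/min, estimated to lie between 4 mL/min and 18 mL/min.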

Compound 4, intrinsic clearance in a liver preparation (reported as CLH), per the amount of preparation that the assay uses: 7.88 mL/min
The estimate for compound 4 lay 1.1-fold (0.03 log units) above the measured number, and the stated range covers the measured number.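

In this assay, 3,4-dimethylphenyl in place of 4-fluorophenyl on a sulfonyl sulfur gives a 6.4-fold higher number from compound 3 to compound 4 (0.81 log units; beyond the scatter), and the step carries over from one core to the other: the same change on two cores in this assay, a 6.9-fold higher number (0.84 log units; beyond the scatter) from compound 2 to compound 1 and a 6.4-fold higher number (0.81 log units; beyond the scatter) from compound 3 to compound 4, 1.1-fold (0.03 log units) apart, within the scatter of two such steps The reverse view of the same square agrees, as chloro in place of fluoro on an aromatic carbon gives a 1.2-fold lower number from compound 1 to compound 4 (0.07 log units; within the scatter), again with no difference between the cores: the same change on two cores in this assay, a 1.1-fold lower number (0.04 log units; within the scatter) from compound 2 to compound 3 and a 1.2-fold lower number (0.07 log units; within the scatter) from compound 1 to compound 4, 1.1-fold (0.03 log units) apart, within the scatter of two such steps This shows that, for these four compounds, the two changes add up without any sign of one altering the other, but it rests on a single pair of cores that differ only by that halogen, so it does not show that the sulfonyl step would hold on a core differing more widely, nor does it explain the rise.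

The compounds shown leave open whether the rise needs both methyl groups or whether one would do. They also leave open what a methoxy group or an amine on that ring would give in this assay.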